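A few compounds are considered here, and "the series" means these few. Any claim that something is new, unique, unknown or untested is made for them only; others in the source may bear on it.

The measured compounds:

compound 1 `CC#CC(CC(=O)O)c1ccc(OCc2ccc(C(=O)N3CCN(C)CC3)s2)cc1` — in a functional assay on HEK293 cells for agonist activity at Free fatty acid receptor 1 (Homo sapiens), read by fluorescence and calcium flux (a higher number here means that more compound is needed for the effect, a lower number that less compound is needed), compound 1 gives > 5000 nM, a limit of the assay rather than a number.
compound 2 `CC#CC(CC(=O)O)c1ccc(OCc2ccc(C(=O)N3CCN(c4ccncc4)CC3)s2)cc1` — in this assay compound 2 gives > 5000 nM, again a limit and not a number.
compound 3 `CC#CC(CC(=O)O)c1ccc(OCc2ccc(C(=O)N3CCN(c4ccccn4)CC3)s2)cc1` — in this assay compound 3 gives 138 nM.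

Among the measured compounds shown here, compound 3 therefore holds the only real number in the set; the other two values sit at the limit of > 5000 nM in this assay, at which 2 of the 3 values shown sit. The steps to it are large: an at least 36-fold lower number from compound 1 to compound 3 (1.55 log units; beyond the scatter) and an at least 36-fold lower number from compound 2 to compound 3 (1.55 log units; beyond the scatter), while a step that the two limits leave unreadable from compound 1 to compound 2.

Compound 4 `CC#CC(CC(=O)O)c1ccc(OCc2ccc(C(=O)N3CCN(c4ccc(OC)cc4)CC3)s2)cc1` carries 4-methoxyphenyl in place of pyridin-2-yl on an amine nitrogen in a ring. For the measured compounds named here, no measured step involves a carbon-only aromatic ring at this nitrogen, so the comparison rests on what the pyridyl isomers show: a change as small as moving the ring nitrogen took the value from a number back to a limit. On that basis compound 4 is expected to be weaker than compound 3, with an 11-fold higher number from compound 3 to compound 4 (1.04 log units; beyond the scatter) as the estimated step. Compound 4 is estimated at 1500 nM, within 300 nM to 8000 nM.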

Compound 4, half-maximal effective concentration: 289 nM
For compound 4 the middle estimate is 5.2-fold (0.72 log units) above the measured one; the measured number lies below the stated range.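

Compound 4 shows that this amine nitrogen in a ring does not need a ring nitrogen in its aromatic group to give a real number in this assay: 4-methoxyphenyl, a six-membered aromatic ring of carbon only, replaces pyridin-2-yl with a 2.1-fold higher number from compound 3 to compound 4 (0.32 log units; beyond the scatter). That modest step stands against an at least 17-fold lower number from compound 2 to compound 4 (1.23 log units; beyond the scatter) and an at least 17-fold lower number from compound 1 to compound 4 (1.23 log units; beyond the scatter), so among the aromatic groups shown here, pyridin-4-yl in compound 2 goes against the pattern of a real number. Compound 2 stays at a limit of the assay, not a number, as does compound 1: the limit of > 5000 nM in this assay, at which 2 of the 4 values shown sit.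

The compounds shown leave open what the methoxy group itself contributes, as plain phenyl and 4-chlorophenyl are not among them. They also leave open whether a saturated ring such as cyclohexyl, or a benzyl group, would serve on this nitrogen.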